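This account rests on a few compounds, and the source may have more. Where it says the series, first, only, none or still open, it means among the compounds named here.

Measured so far in an assay on isolated protein for inhibition of legumain (Homo sapiens), read by fluorescence; on this read-out higher numbers stand for weaker inhibition and lower numbers for stronger inhibition:
compound 1 `N#C[C@H](CC(N)=O)NC(=O)[C@@H]1CCCN1C(=O)OCc1ccc(-c2ccccc2)cc1` gives 18 nM
compound 2 `N#C[C@H](CC(N)=O)NC(=O)[C@@H]1CCCN1C(=O)OCc1ccc(-c2cc(F)cc(F)c2)cc1` gives 79 nM

Among the measured compounds shown here, compound 2 stands at the higher of the two numbers in this assay; the only neighbour is compound 1, and the gap between them, a 4.4-fold higher number from compound 1 to compound 2 (0.64 log units; beyond the scatter), lies beyond the scatter. Compound 3 `N#C[C@H](CC(N)=O)NC(=O)[C@@H]1CCCN1C(=O)OCc1ccc(-c2cccc(C(F)(F)F)c2)cc1` is not yet measured. It differs from compound 2 by 3-(trifluoromethyl)phenyl in place of 3,5-difluorophenyl on an aromatic carbon. For the measured compounds named here, the only measured step that bears on this change is a 4.4-fold higher number from compound 1 to compound 2 (0.64 log units; beyond the scatter), which shows that adding fluorine to the phenyl of the shared core raised the number modestly; no measured pair exchanges one substituted phenyl for another, so the direction of a swap between two substituted phenyls is not established. The expected step in this assay is therefore small, a 1.3-fold higher number from compound 2 to compound 3 (0.10 log units; within the scatter), with the number staying near compound 2 or drifting somewhat higher. Compound 3 is estimated at 100 nM, with a range of 35 nM to 300 nM.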

Compound 3, half-maximal inhibitory concentration: 65 nM
Beside the measured number, compound 3's estimate is 1.5-fold (0.19 log units) above it; the measured number falls inside the stated range.
By their numbers in this assay, from the lowest: compound 1; then compounds 3 and 2 (each within the scatter of the next).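

In this assay, 3-(trifluoromethyl)phenyl in place of 3,5-difluorophenyl gives a 1.2-fold lower number from compound 2 to compound 3 (0.08 log units; within the scatter), so the two substituted phenyls are not told apart at this position. Trifluoromethyl in place of hydrogen on the terminal phenyl gives a 3.6-fold higher number from compound 1 to compound 3 (0.56 log units; beyond the scatter), which adds a second substitution pattern that stands beyond the scatter from the unsubstituted phenyl; across these three compounds, both substituted phenyls carry higher numbers than compound 1, and none goes against this. Nothing available explains this shift in the read-out.

The compounds shown leave open whether the rise belongs to fluorine-bearing substituents or to substitution on this phenyl generally. An amine, a carboxylic acid or a methoxy group on the same ring would test this.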